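This account rests on a few compounds, and the source may have more. Where it says the series, first, only, none or still open, it means among the compounds named here.

Measured compounds in this series:

compound 1, `CN(C(=O)c1ccc(Br)cc1)c1ccc2[nH]c(-c3n[nH]c4ccccc34)cc2n1` — 1080 nM
compound 2, `COc1ccc(OC)c(S(=O)(=O)N(C)c2ccc3[nH]c(-c4n[nH]c5ccccc45)cc3n2)c1` — 840 nM
compound 3, `COc1ccc(S(=O)(=O)N(C)c2ccc3[nH]c(-c4n[nH]c5ccccc45)cc3n2)c(OC)c1` — 5180 nM

In a functional assay on HL-60 cells (Homo sapiens) for antiproliferative activity, read by MTT assay, with a stated time of 72 h (a lower number here means a stronger inhibitor, a higher number a weaker inhibitor), compound 1 stands second highest of the three numbers. Its nearest neighbour is compound 2, whose value lies within the scatter of that of compound 1, so no order between the two can be read; compound 3 gives the highest number, beyond the scatter from compound 1.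

The unmeasured compound 4, `CN(C(=O)Nc1ccccc1)c1ccc2[nH]c(-c3n[nH]c4ccccc34)cc2n1`, differs from compound 1 by anilino in place of 4-bromophenyl on a carbonyl carbon. Among the measured compounds shown here, the only measured step, a 6.2-fold higher number from compound 2 to compound 3 (0.79 log units; beyond the scatter), concerns a rearrangement of methoxy groups on a sulfonyl sulfur and says nothing about an exchange at the carbonyl carbon; no measured pair bears directly on the present change. The shared core is kept and the replacing group matches the leaving group in size, so nothing in the data argues for a step beyond the scatter in either direction.

The step from compound 1 to compound 4 is therefore expected to be a 1.0-fold higher number from compound 1 to compound 4 (0.01 log units; within the scatter). Compound 4 is estimated at 1100 nM, with a range from 300 nM to 4500 nM, the width reflecting that the change is unsupported by any measured step.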

Compound 4, half-maximal inhibitory concentration: 8.3 nM
The estimate for compound 4 lay 130-fold (2.12 log units) above the measured number; the whole stated range lies above it.
By their numbers in this assay, from the lowest: compound 4; then compounds 2 and 1 (each within the scatter of the next); then compound 3.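

In this assay, among the compounds shown here, the group on the carbonyl carbon proves far more influential than the earlier compounds could show: anilino in place of 4-bromophenyl gives a 130-fold lower number from compound 1 to compound 4 (2.11 log units; beyond the scatter), the largest step so far. The two groups match in heavy-atom count and in their six-membered aromatic ring of carbon only, so a large step arises here without a change in those counts, while the exchange removes the bromine and brings in a nitrogen with one hydrogen-bond donor. Nothing available explains the step.

The step cannot be assigned to the loss of the bromine or to the gain of the nitrogen; phenyl and 4-bromoanilino on the same carbonyl carbon would separate the two. On these data alone, whether benzylamino, with its longer chain, is tolerated also remains open.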